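Spiro core series: triazolylmethyl amide variation in MCF7 proliferation

The compounds below may be only part of what the source reports. "The series", "measured", "known", "first", "only" and "open" are said of these compounds alone.

Two compounds of this series carry a measured value. Compound 1 `N#CC1=C(N)Oc2c(c3nc4ccccc4nc3c3ccccc23)C12C(=O)N(Cc1cnnn1-c1cccc(Cl)c1)c1ccccc12` gives in a functional assay on MCF7 cells (Homo sapiens) for antiproliferative activity, read by MTT assay, with a stated time of 48 h (on this read-out lower numbers stand for stronger inhibition and higher numbers for weaker inhibition), a half-maximal inhibitory concentration of 43600 nM. Compound 2 `CCc1ccccc1-n1nncc1CN1C(=O)C2(C(C#N)=C(N)Oc3c(N)cc4nc5ccccc5nc4c32)c2ccccc21` gives in this assay a value of 24600 nM. Among the compounds with values here, the two numbers lie within the usual scatter of each other, so compound 2 is not set apart from compound 1 on this read-out, and no step between compounds differing in one place can be drawn from them.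

Compound 3 `N#CC1=C(N)Oc2c(N)cc3nc4ccccc4nc3c2C12C(=O)N(Cc1cnnn1-c1ccc(F)c(Cl)c1)c1ccccc12` is not yet measured. Relative to compound 2 the change is 3-chloro-4-fluorophenyl in place of 2-ethylphenyl on an aromatic nitrogen. Compound 1 carries a related halogenated phenyl on the same aromatic nitrogen, and its value sits close to that of compound 2, which offers no sign that such an exchange moves the read-out far.

For compound 3 the expected step in this assay is therefore a 1.1-fold higher number from compound 2 to compound 3 (0.06 log units; within the scatter), that is, no change beyond the scatter in either direction. Compound 3 is accordingly estimated at 28000 nM, with a range from 9000 nM to 85000 nM.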

Compound 3, half-maximal inhibitory concentration: 17800 nM
Estimate against measurement, compound 3: 1.6-fold (0.20 log units) above, and the stated range covers the measured number.
By their numbers in this assay, from the lowest: compounds 3, 2 and 1 (each within the scatter of the next, the first and the last beyond it).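

Within the data shown here, the exchange of 2-ethylphenyl for 3-chloro-4-fluorophenyl on the aromatic nitrogen gives a 1.4-fold lower number from compound 2 to compound 3 (0.14 log units; within the scatter) in this assay, and this is the first step that can be read at a single place with the rest of the structure held constant. The read-out does not tell these two phenyl groups apart, although one carries an ethyl group and the other carries chlorine and fluorine, and each counts 8 heavy atoms with no hydrogen-bond donors or acceptors. No measured property of these compounds bears on this result, so the data offer no account of it.

The compounds shown leave open whether a group of another kind on this nitrogen, such as a phenyl bearing a carboxylic acid or an aminomethyl group, or a longer alkyl chain in place of the phenyl ring, would give a number beyond the scatter of compound 2. They also leave open what chlorine or fluorine contributes alone, and how an unsubstituted phenyl would read at this position.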